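Adding an ester chain to compound 2

A few compounds are considered here, and "the series" means these few. Any claim that something is new, unique, unknown or untested is made for them only; others in the source may bear on it.

Compound 1 `Cc1cc2[nH]nc(N)c2c(=O)[nH]1` gives 56% in an assay on isolated protein for inhibition of ribosomal protein S6 kinase alpha-5 (Homo sapiens), read by mobility shift assay, tested at 30 uM (on this read-out lower numbers stand for less inhibition and higher numbers for more inhibition at the one concentration tested (going by the name of the read-out)), the highest of the three numbers. Compound 2 `Cc1cc2c(c(N)nn2C)c(=O)[nH]1` gives 4%, the second highest; it is close to compound 3 `Cn1nc(N)c2c(=O)[nH]c(-c3ccccn3)cc21`, which gives -4%, and far from compound 1. The step of a number 52 percentage points lower from compound 1 to compound 2 (beyond the scatter) is large, whereas the step of a number 8 percentage points lower from compound 2 to compound 3 (within the scatter) stays within the scatter. Compound 4 `COC(=O)CCc1c(C)[nH]c(=O)c2c(N)nn(C)c12` differs from compound 2 by 2-(methoxycarbonyl)ethyl in place of hydrogen on an aromatic carbon. For the measured compounds named here, the only step that bears on it is the change on an aromatic carbon of the same ring from compound 2 to compound 3, which was small. Compound 4 is therefore expected to show a number 1 percentage points lower from compound 2 to compound 4 (within the scatter), no change beyond the scatter. The estimate for compound 4 is 3%, ranging from -12% to 18%.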

Compound 4, a percentage reported as inhibition, at one concentration (the size of the read-out at that concentration, not a potency): 7%
The estimate for compound 4 lay 4 percentage points below the measured number, and the stated range covers the measured number.
By their numbers in this assay, from the lowest: compounds 3, 2 and 4 (each within the scatter of the next, the first and the last beyond it); then compound 1.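

In this assay, 2-(methoxycarbonyl)ethyl on this aromatic carbon, ortho to a methyl group and ortho to a fused ring, gives a number 3 percentage points higher from compound 2 to compound 4 (within the scatter). The earlier compounds shown here carried no substituent at this carbon, and these results show that this chain of 6 heavy atoms leaves compound 4 indistinguishable from compound 2. Nothing available explains this result.

As far as these compounds go, it remains open whether the free carboxylic acid, an amine or a longer chain at this carbon would read differently. Also open, from the compounds shown here alone, is how the same chain would read on compound 1, which keeps hydrogen on the aromatic nitrogen.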